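This account rests on a few compounds, and the source may have more. Where it says the series, first, only, none or still open, it means among the compounds named here.

Values so far in a functional assay on PC-3 cells (Homo sapiens) for inhibition, read by sulforhodamine B assay; a higher number here means a weaker inhibitor of growth, a lower number a stronger inhibitor of growth:
- compound 1 `c1ccc(-c2ccc(-c3ccc(-c4nc5ccccc5[nH]4)cc3)cc2)cc1` gives 41200 nM
- compound 2 `FC(F)(F)Oc1ccc(-c2ccc(-c3ccc(-c4nc5ccccc5[nH]4)cc3)cc2)cc1` gives 100000 nM
- compound 3 `Oc1cccc2[nH]c(-c3ccc(-c4ccc(-c5ccccc5)cc4)cc3)nc12` gives 1240 nM

Of these three, compound 3 has the lowest number, so it inhibits growth most strongly, and the other two sit well above it. Compound 4 `COc1ccc(-c2ccc(-c3ccc(-c4nc5c(O)cccc5[nH]4)cc3)cc2)cc1` has not been measured yet. It differs from compound 3 in one place: methoxy in place of hydrogen on an aromatic carbon (methoxy in place of hydrogen on an aromatic carbon, which reads as phenyl to 4-methoxyphenyl).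

Within the data shown here, two measured steps bear on this change. The closer guide is a 2.4-fold higher number from compound 1 to compound 2 (0.39 log units; beyond the scatter), where trifluoromethoxy replaces hydrogen on an aromatic carbon. That step is modest and raises the number. The other, a 33-fold lower number from compound 1 to compound 3 (1.52 log units; beyond the scatter), is large and adds the hydroxy that compound 4 keeps. Compound 3 already carries that hydroxy, so this step is a weaker guide to the coming change. Among the measured compounds shown here, no methoxy compound has been measured here, and the trifluoromethoxy step was measured without the hydroxy, so this guide is loose.

The expected move is small and upward, given as a 1.6-fold higher number from compound 3 to compound 4 (0.21 log units; within the scatter), and it may not clear the usual scatter. Compound 4 is estimated at 2000 nM, with an expected range from 700 nM to 6000 nM in this assay.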

Compound 4, concentration for 50% growth inhibition: 6610 nM
Estimate against measurement, compound 4: 3.3-fold (0.52 log units) below, outside the stated range (above it).
By their numbers in this assay, from the lowest: compound 3; then compound 4; then compound 1; then compound 2.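

In this assay, methoxy on an aromatic carbon of the six-membered carbon ring, para to a large group, gives a 5.3-fold higher number from compound 3 to compound 4 (0.73 log units; beyond the scatter), so compound 3's hydrogen at this position cannot be exchanged for methoxy without a loss of growth inhibition that stands clear of the scatter. Among these compounds, the only earlier change on an outer ring, a 2.4-fold higher number from compound 1 to compound 2 (0.39 log units; beyond the scatter), concerned trifluoromethoxy on a parent lacking the hydroxy, so the new step adds a second group that raises the number and shows that this rise also occurs with the hydroxy present, at least in these two pairs. No measurement at hand explains why the number rises with methoxy.

The compounds shown leave open whether methoxy would move the number as far on the core without the hydroxy, since only the trifluoromethoxy step speaks for that parent. They also leave open whether every group at this position raises the number, or whether a fluorine atom, an amine, a carboxylic acid or a longer chain such as ethoxy would behave differently.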